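Amide aryl swap on a shared chloro core

The source may report more compounds than this note shows. Statements on the series, on what has been measured and on what is new or still open speak of the compounds shown alone.

Compound 1 `O=C(Nc1ccc(Cl)c(-c2nnc3c(Cl)cccn23)c1)c1ccc(C(F)(F)F)cc1Cl`: > 100000 nM in a functional assay on MDA-MB-468 cells (Homo sapiens) for antiproliferative activity, read by MTT assay, with a stated time of 72 h; a higher number here means a weaker inhibitor, a lower number a stronger inhibitor
Compound 2 `Cc1nc(C(=O)Nc2ccc(Cl)c(-c3nnc4c(Cl)cccn34)c2)cs1`: > 100000 nM
Compound 3 `O=C(Nc1ccc(Cl)c(-c2nnc3c(Cl)cccn23)c1)c1ccc(C(F)(F)F)cc1F`: 22300 nM

Compound 2 gives only a limit in this assay, > 100000 nM, and so its true number is not known. Compound 1 likewise reaches only a limit, > 100000 nM. Among the compounds with values here, compound 3 is the one compound with a measured number, 22300 nM. Within the data shown here, the only measured step, an at least 4.4-fold lower number from compound 1 to compound 3 (0.65 log units; beyond the scatter), concerns a halogen on the aryl amide and does not touch the change now considered. Compound 4 `CS(=O)(=O)c1ccc(C(=O)Nc2ccc(Cl)c(-c3nnc4c(Cl)cccn34)c2)cc1` differs from compound 2 by 4-(methylsulfonyl)phenyl in place of 2-methyl-1,3-thiazol-4-yl on a carbonyl carbon. Among the measured compounds shown here, since two of three values sit at the limit (the limit of > 100000 nM in this assay, at which 2 of the 3 values shown sit), and no step covers this swap, compound 4 is expected to stay weak, at roughly 60000 nM (range 15000 nM to 200000 nM), an expected step of an at least 1.6-fold lower number from compound 2 to compound 4 (0.22 log units; that floor lies within the scatter).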

Compound 4, half-maximal inhibitory concentration: > 100000 nM
Compound 4: only a limit was reported; the forecaster's own chance of this, stated with the estimate: 45%; middle value at least 1.6-fold (0.22 log units) away from the limit.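

Compound 2 and compound 4 both stop at a limit, so no step can be read between them: the limit of > 100000 nM in this assay, at which 3 of the 4 values shown sit. As far as these compounds go, the true numbers of compound 2 and compound 4 remain open, and so does how these two amide groups compare.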